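A few compounds are considered here, and "the series" means these few. Any claim that something is new, unique, unknown or untested is made for them only; others in the source may bear on it.

Compound 1 `Nc1ncnc2c1c(-c1cnc3[nH]ccc3c1)nn2CCCCCC(=O)NO` gives 63700 nM in a functional assay on HCT-116 cells (Homo sapiens) for inhibition, read by MTT assay, with a stated time of 72 h; a higher number here means a weaker inhibitor, a lower number a stronger inhibitor. Compound 2 `Nc1ncnc2c1c(-c1cnc3[nH]ccc3c1)nn2CCCCCCC(=O)NO` differs from it by (hydroxycarbamoyl)methyl in place of hydroxycarbamoyl on a saturated chain carbon, five bonds along the chain from an aromatic nitrogen and gives 9860 nM in this assay, a step of a 6.5-fold lower number from compound 1 to compound 2 (0.81 log units; beyond the scatter). Compound 3 `Nc1nc2cc(-c3nn(CCCCC(=O)NO)c4ncnc(N)c34)ccc2o1` carries a different core; the difference between the two cores is not broken down here. In this assay compound 3 gives 34000 nM. Compound 4 `Nc1nc2cc(-c3nn(CCCCCC(=O)NO)c4ncnc(N)c34)ccc2o1` differs from compound 3 by (hydroxycarbamoyl)methyl in place of hydroxycarbamoyl on a saturated chain carbon, four bonds along the chain from an aromatic nitrogen, the same kind of change as that from compound 1 to compound 2, though here the place lies four rather than five bonds along the chain from the aromatic nitrogen. Compound 4 is expected to show a step of a 5.7-fold lower number from compound 3 to compound 4 (0.75 log units; beyond the scatter), resting on the step of a 6.5-fold lower number from compound 1 to compound 2 (0.81 log units; beyond the scatter) seen with the other core. For compound 4 the estimate is 6000 nM, with a range from 2000 nM to 20000 nM.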

Compound 4, half-maximal inhibitory concentration: 21500 nM
Estimate against measurement, compound 4: 3.6-fold (0.55 log units) below; the whole stated range lies below it.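

On the core of compound 3, (hydroxycarbamoyl)methyl in place of hydroxycarbamoyl gives a 1.6-fold lower number from compound 3 to compound 4 (0.20 log units; within the scatter) in this assay, so this pair cannot be told apart there. The step seen on the core of compound 1 therefore did not carry over in size to this core, and the two steps differ: the same change on two cores in this assay, a 6.5-fold lower number (0.81 log units; beyond the scatter) from compound 1 to compound 2 and a 1.6-fold lower number (0.20 log units; within the scatter) from compound 3 to compound 4, 4.1-fold (0.61 log units) apart, beyond the scatter of two such steps

This rests on a single pair for each core, so it shows that the step was not the same size in these two cases, but it does not show why, or how the change would behave on any other core.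

The compounds shown leave open how a longer chain would behave on either core. They also leave open how a carboxylic acid in place of the hydroxycarbamoyl end would read in this assay.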